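Swapping a Spiro Carbon Group for Piperidine on the Amide

The source may report more compounds than this note shows. Statements on the series, on what has been measured and on what is new or still open speak of the compounds shown alone.

Of the compounds shown here, three sharing one core have been tested in an assay on HEK293 cells for positive allosteric modulation of metabotropic glutamate receptor 5 (Homo sapiens), read by FLIPR; on this read-out higher numbers stand for an effect only at larger amounts of compound and lower numbers for an effect already at smaller amounts. Compound 1 `O=C(C1CCC2(CCC2)CC1)N1CC(c2nc(-c3cccc(Cl)c3)no2)C1` gives 1100 nM, the highest of the three numbers. Compound 2 `O=C(C1CCC(C(F)(F)F)CC1)N1CC(c2nc(-c3cccc(F)c3)no2)C1` gives 680 nM, which lies within the usual scatter of compound 1, so these two cannot be ranked against each other. Compound 3 `CC1CCCCC1C(=O)N1CC(c2nc(-c3cccc(F)c3)no2)C1` gives 540 nM, a number lower than that of compound 1 by more than the scatter.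

Compound 4 `O=C(N1CCCCC1)N1CC(c2nc(-c3cccc(Cl)c3)no2)C1` has not yet been measured. Relative to compound 1 it differs at one place: a group of 6 heavy atoms (5 carbon, 1 nitrogen; one six-membered non-aromatic ring with 1 hetero atom) in place of a group of 9 heavy atoms (9 carbon; one four-membered non-aromatic ring of carbon only, one six-membered non-aromatic ring of carbon only), on a carbonyl carbon. For the measured compounds named here, no measured pair shows a change of this kind, so the size of the step is uncertain. A step of a 1.5-fold higher number from compound 1 to compound 4 (0.16 log units; within the scatter) is expected, roughly at the edge of the scatter, toward a somewhat higher number. Compound 4 is estimated at 1600 nM, with a range from 500 nM to 5000 nM.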

Compound 4, half-maximal effective concentration: 370 nM
The estimate for compound 4 lay 4.3-fold (0.64 log units) above the measured number, and the stated range ends above it.
By their numbers in this assay, from the lowest: compounds 4, 3, 2 and 1 (each within the scatter of the next, the first and the last beyond it).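

For the compounds shown here, on the carbonyl carbon, piperidin-1-yl in place of the carbon-only two-ring group gives a 3.0-fold lower number from compound 1 to compound 4 (0.47 log units; beyond the scatter) and is the first step here with the rest of the molecule unchanged. This place therefore accepts a smaller ring holding a nitrogen, with no rise in the number. No measurement at hand gives a reason for this step.

Still open, as far as these compounds go, is whether the ring nitrogen or the smaller size carries the step. Cyclohexyl at this place would separate the two, while pyrrolidin-1-yl or morpholin-4-yl would test how far the ring can change.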